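Spiro-hydantoin side chain: from hydroxyethyl to nitrobenzyl

The compounds below may be only part of what the source reports. "The series", "measured", "known", "first", "only" and "open" are said of these compounds alone.

Measured compounds:
compound 1, `COC(=O)C1C(=O)C(C(=O)OC)[C@H](c2ccccn2)N(CCCCCCCC(=O)O)[C@@H]1c1ccccn1`, giving 33.8 uM in an ADME assay on J774.1 cells (Mus musculus) for cytotoxicity, with a stated time of 48 h; a higher number here means that more compound is needed for the effect, a lower number that less compound is needed
compound 2, `C[C@@H]1CC2(C[C@H](C)N1)C(=O)N(CCO)C(=O)N2Cc1ccccc1`, giving > 100 uM in this assay

The two measured compounds share no common core, so their values stand side by side without a connecting step. Compound 1 gives a number in this assay. For compound 2 the assay reports only a limit, > 100 uM, at which one of the two values shown sits (the limit of > 100 uM in this assay, at which 1 of the 2 values shown sits). Where compound 2 actually stands is therefore not known beyond that boundary.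

Compound 3, `C[C@@H]1CC2(C[C@H](C)N1)C(=O)N(Cc1ccc([N+](=O)[O-])cc1)C(=O)N2Cc1ccccc1`, is not yet measured. It differs from compound 2 in one place: 4-nitrophenyl in place of hydroxymethyl on a saturated chain carbon bound to an amide-type nitrogen in a ring. Cut one bond further out, the change reads 2-hydroxyethyl to 4-nitrobenzyl on the amide-type nitrogen of the shared core.

Going by the values given here, no step between measured compounds is available to calibrate this change. With compound 2 resting at a limit, an expected step toward more compound needed cannot be seen, and only a move toward less compound needed would show as a number. The expectation here is a modest move in that direction, perhaps no further than the scatter, from compound 2 to compound 3 of an at least 1.4-fold lower number from compound 2 to compound 3 (0.15 log units; that floor lies within the scatter). Compound 3 is accordingly estimated at 70 uM, within a range of 25 uM to 200 uM.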

Compound 3, concentration for half-maximal effect: 42.4 uM
Compound 3: middle estimate off by 1.7-fold (0.22 log units), on the high side; low and high end bracket the measured number.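

Compound 2 gives only a limit in this assay, > 100 uM, so on its own it showed no measurable effect to compare against. Compound 3 shows that the amide-type nitrogen of the shared core is a place where a change can bring the read-out into the measurable range: going from 2-hydroxyethyl to 4-nitrobenzyl, which puts a six-membered aromatic ring of carbon only where there was none, gives an at least 2.3-fold lower number from compound 2 to compound 3 (0.37 log units; beyond the scatter). The size of this step is a floor and not a full measure, and the true distance may be larger, because one end of it rests on a boundary: the limit of > 100 uM in this assay, at which 1 of the 3 values shown sits.

The hydroxymethyl group leaves and the 4-nitrophenyl group enters in a single step, and the compounds shown cannot separate the loss of the hydroxyl from the gain of the ring or of the nitro group. On these data alone, a plain benzyl group, a 4-aminobenzyl group or a longer chain ending in a hydroxyl on the same nitrogen would be needed to tell these apart, and it remains open whether any of them would keep the lower number.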